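The compounds below may be only part of what the source reports. "The series", "measured", "known", "first", "only" and "open" are said of these compounds alone.

Measured compounds:
compound 1 `CC(C)(C)c1ccc(C(=O)N2CCC3(CC2)C(=O)N(CC(=O)NCCCN)CN3c2ccccc2)cc1`: 4200 nM
compound 2 `CC(C)(C)c1ccc(C(=O)N2CCC3(CC2)C(=O)N(CC(=O)NCCCCCNS(C)(=O)=O)CN3c2ccccc2)cc1`: 5500 nM
compound 3 `CC(C)(C)c1ccc(C(=O)N2CCC3(CC2)C(=O)N(CC(=O)NCNS(C)(=O)=O)CN3c2ccccc2)cc1`: 3200 nM

All three share one core and differ only in the tail carried by the amide-type nitrogen. In an assay on HEK293 cells for displacement of a labelled ligand from NPC1-like intracellular cholesterol transporter 1 (Homo sapiens) (a lower number here means a stronger inhibitor, a higher number a weaker inhibitor), compound 3 gives the lowest of the three numbers, but the steps reaching it, a 1.3-fold lower number from compound 1 to compound 3 (0.12 log units; within the scatter) and a 1.7-fold lower number from compound 2 to compound 3 (0.24 log units; within the scatter), both lie within the scatter, as does a 1.3-fold higher number from compound 1 to compound 2 (0.12 log units; within the scatter); no order among the three is claimed.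

Compound 4 `CCC1CCCN(C(=O)CN2CN(c3ccccc3)C3(CCN(C(=O)c4ccc(C(C)(C)C)cc4)CC3)C2=O)C1` is the next step from compound 3: 3-ethylpiperidin-1-yl in place of ((methanesulfonamido)methyl)amino on a carbonyl carbon. The three measured steps bear on it only loosely: each swaps one tail for another on the same chain, and none moved the number beyond the scatter. None of them, however, exchanges the whole ((methanesulfonamido)methyl)amino portion for a six-membered non-aromatic ring with no hydrogen-bond donors or acceptors, so the change to compound 4 is larger than anything measured. The tail has so far been tolerant of variation, so a step of modest size at most is expected, with direction undetermined, a 1.1-fold higher number from compound 3 to compound 4 (0.04 log units; within the scatter). Compound 4 is therefore estimated at 3500 nM in this assay, within 1000 nM to 12000 nM.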

Compound 4, half-maximal inhibitory concentration: 3900 nM
Beside the measured number, compound 4's estimate is 1.1-fold (0.05 log units) below it; the measured number falls inside the stated range.
By their numbers in this assay, from the lowest: compounds 3, 4, 1 and 2 (each within the scatter of the next).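

On the carbonyl carbon whose other neighbour is a saturated chain carbon, open-chain tails can be exchanged for a ring, 3-ethylpiperidin-1-yl, and in this assay this gives a 1.2-fold higher number from compound 3 to compound 4 (0.09 log units; within the scatter) and a 1.4-fold lower number from compound 2 to compound 4 (0.15 log units; within the scatter) and a 1.1-fold lower number from compound 1 to compound 4 (0.03 log units; within the scatter) in the three comparisons. The earlier compounds shown here all kept hydrogen-bond donors in the group at this place, whereas 3-ethylpiperidin-1-yl has none, and the numbers do not separate these tails. Nothing measured here accounts for this tolerance.

Going by these compounds, it remains open whether a carboxylic acid on that carbonyl carbon, or a plain piperidin-1-yl or morpholin-4-yl in place of 3-ethylpiperidin-1-yl, would stay within the scatter of these numbers. On these data alone, it is also open whether any group at this place can move the number beyond the scatter.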